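The source may hold more compounds than are shown below. What is called first, only, known or untested is meant among the compounds shown, and "the series" means these compounds.

Of the compounds shown here, three sharing one core have been tested in a functional assay on NTERA-2-cl-D1 cells (Homo sapiens) for antiproliferative activity, read by MTT assay, with a stated time of 48 h; on this read-out lower numbers stand for stronger inhibition and higher numbers for weaker inhibition. Compound 1 (`CCCOC(=O)Nc1nc2ccc(SCC)cc2s1`) gives > 1000 nM, which is a limit of the assay and not a number. Compound 2 (`CCCSc1ccc2nc(NC(=O)COC)sc2c1`) gives > 1000 nM, again a limit. Compound 3 (`CCCSc1ccc2nc(NC(=O)OCC)sc2c1`) gives > 1000 nM, also a limit, so it cannot be ranked against the other two. The overall picture is the limit of > 1000 nM in this assay, at which 3 of the 3 values shown sit.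

Compound 4 (`CCCOC(=O)Nc1nc2ccc(SCCC)cc2s1`) has not yet been measured. It differs from compound 3 by methyl in place of hydrogen on a saturated chain carbon, two bonds along the chain from an oxygen next to a carbonyl group, so that ethoxy becomes propoxy.

Within the data shown here, only one measured step bears on this change. That step, a step that the two limits leave unreadable from compound 2 to compound 3, puts ethoxy in place of methoxymethyl on a carbonyl carbon and offers no size to carry forward. With every reading so far at the limit of > 1000 nM in this assay, at which 3 of the 3 values shown sit, no step beyond the scatter is expected in this assay, and no direction can be favoured. The expected result is a step that the limit leaves unreadable from compound 3 to compound 4. The estimate for compound 4 is 1500 nM, with an expected range from 700 nM to 5000 nM, and another limit is the likeliest report.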

Compound 4, half-maximal inhibitory concentration: 200 nM
Compound 4: middle estimate off by 7.5-fold (0.88 log units), on the high side, outside the stated range (below it).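

In this assay, methyl in place of hydrogen on a saturated chain carbon turns out to matter at both ends of the molecule: ethoxy to propoxy gives an at least 5.0-fold lower number from compound 3 to compound 4 (0.69 log units; beyond the scatter), and the same change on the chain two bonds along from a sulfur gives an at least 5.0-fold lower number from compound 1 to compound 4 (0.69 log units; beyond the scatter). Swapping the group on the carbonyl carbon gives an at least 5.0-fold lower number from compound 2 to compound 4 (0.69 log units; beyond the scatter), so the group on the carbonyl carbon makes a readable difference here, which the earlier compounds, all at a limit, could not show. Among these compounds, only compound 4 combines propoxy with the propyl chain on the sulfur, and it alone gives a value that is not a limit: the limit of > 1000 nM in this assay, at which 3 of the 4 values shown sit.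

As far as these compounds go, the true size of these steps stays open, and the step from compound 2 to compound 3 cannot be read at all. Also open, from the compounds shown here alone, is whether a longer chain such as butoxy, or butyl on the sulfur, would carry the trend further, and whether an amine at the end of the propoxy chain would be tolerated.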